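Adding a Methyl to the Weakest Exposure Acid

The compounds below may be only part of what the source reports. "The series", "measured", "known", "first", "only" and "open" are said of these compounds alone.

In an ADME assay on the whole organism (strain CD-1) for pharmacokinetics, with Mus musculus as the target, at a dose of 3 mg/kg by the intravenous route (a higher number here means more compound in the circulation at the dose given, a lower number less compound in the circulation), compound 3 (`CN(Cc1ccccc1OCCC/C=C/C(=O)O)C(=O)c1ccc(-c2ccco2)cc1`) gives 750 ng.h/mL and has the lowest of the three measured numbers. Compound 1 (`C[C@@H](CCCOc1ccccc1CN(C)C(=O)c1ccc(-c2ccco2)cc1)CC(=O)O`) gives 30800 ng.h/mL and compound 2 (`CN(Cc1ccccc1OCCC[C@@H]1C[C@H]1C(=O)O)C(=O)c1ccc(-c2ccco2)cc1`) gives 40500 ng.h/mL in comparison.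

Compound 4 (`C/C(=C\C(=O)O)CCCOc1ccccc1CN(C)C(=O)c1ccc(-c2ccco2)cc1`) differs from compound 3 in one place: 2-carboxy-1-methylethenyl in place of 2-carboxyethenyl on a saturated chain carbon, three bonds along the chain from an oxygen on an aromatic ring.

Changes measured at this same place give a 41-fold lower number from compound 1 to compound 3 (1.61 log units; beyond the scatter) and a 54-fold lower number from compound 2 to compound 3 (1.73 log units; beyond the scatter) as two large steps, while a 1.3-fold higher number from compound 1 to compound 2 (0.12 log units; within the scatter) stays within the scatter. Among the measured compounds shown here, no measured step adds a methyl alone, so those steps show only how far the number can move here, not what this change will do.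

A moderate rise is expected, smaller than those two large steps, and the estimated step in this assay is a 5.3-fold higher number from compound 3 to compound 4 (0.73 log units; beyond the scatter) (a rough expectation). The estimate for compound 4 is 4000 ng.h/mL (expected range 800 ng.h/mL to 25000 ng.h/mL).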

Compound 4, area under the concentration-time curve: 4700 ng.h/mL
Estimate against measurement, compound 4: 1.2-fold (0.07 log units) below; measured number inside the range.
By their numbers in this assay, from the lowest: compound 3; then compound 4; then compounds 1 and 2 (each within the scatter of the next).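

In this assay, the change from 2-carboxyethenyl to 2-carboxy-1-methylethenyl gives a 6.3-fold higher number from compound 3 to compound 4 (0.80 log units; beyond the scatter), so adding only a methyl at this position is enough to move the number beyond the scatter. That rise closes only part of the gap to the other two acids, with a 6.6-fold lower number from compound 1 to compound 4 (0.82 log units; beyond the scatter) and an 8.6-fold lower number from compound 2 to compound 4 (0.94 log units; beyond the scatter) still separating them from the new compound. Nothing available here explains why the added methyl raises the number.

The compounds shown leave open whether an ethyl group or a chlorine atom in place of this methyl would raise the number further or lower it. They also leave open whether a longer chain between the oxygen on the aromatic ring and 2-carboxy-1-methylethenyl would keep the rise.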